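This account rests on a few compounds, and the source may have more. Where it says the series, first, only, none or still open, it means among the compounds named here.

In an ADME assay on DU-145 cells (Homo sapiens) for cytotoxicity, read by MTT assay, with a stated time of 72 h (a higher number here means a weaker inhibitor, a lower number a stronger inhibitor), compound 2 `COc1ccc(C2=C(c3cc(OC)c(OC)c(OC)c3)C(=O)C(OC(C)=O)C2)cc1F` gives 16 ug/mL, and compound 3 `COc1ccc(C2=C(c3cc(OC)c(OC)c(OC)c3)C(=O)C(O)C2)cc1F` gives 27 ug/mL. Compound 1 `COc1ccc(C2=C(c3cc(OC)c(OC)c(OC)c3)C(=O)C(OC(C)=O)C2)cc1OC(C)C` reaches only a limit in this assay, namely > 100 ug/mL. The cores of compound 2 and compound 3 differ in one place: hydrogen in place of acetyl on an oxygen on a saturated carbon, and this gives a 1.7-fold higher number from compound 2 to compound 3 (0.23 log units; within the scatter). The change from compound 2 to compound 1 is isopropoxy in place of fluoro on an aromatic carbon, and it gives an at least 6.2-fold higher number from compound 2 to compound 1 (0.79 log units; beyond the scatter), with compound 1 sitting at the limit of > 100 ug/mL in this assay, at which 1 of the 3 values shown sits. Compound 4 `COc1ccc(C2=C(c3cc(OC)c(OC)c(OC)c3)C(=O)C(O)C2)cc1OC(C)C` carries the same change made on the core of compound 3: isopropoxy in place of fluoro on an aromatic carbon. The step from compound 3 to compound 4 is expected to be a 5.6-fold higher number from compound 3 to compound 4 (0.74 log units; beyond the scatter), an estimate resting on an at least 6.2-fold higher number from compound 2 to compound 1 (0.79 log units; beyond the scatter) in this assay. Compound 4 is therefore expected to give about 150 ug/mL in this assay, estimated between 60 ug/mL and 400 ug/mL, and most likely reported only as a limit.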

Compound 4, half-maximal inhibitory concentration: > 100 ug/mL
Compound 4 ended at the assay's limit; the forecaster's own chance of this, stated with the estimate: 70%; the middle value does not contradict the limit.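

In this assay, isopropoxy in place of fluoro on the core of compound 3 gives an at least 3.7-fold higher number from compound 3 to compound 4 (0.56 log units; beyond the scatter), so the change is not confined to the acetylated core of compound 2. On both cores shown, it moves the number in the same direction: the same change on two cores in this assay, an at least 6.2-fold higher number (0.79 log units; beyond the scatter) from compound 2 to compound 1 and an at least 3.7-fold higher number (0.56 log units; beyond the scatter) from compound 3 to compound 4; the limit leaves it open whether they differ. The size of the change on each core remains unresolved, and so does any difference between the cores, as both isopropoxy compounds give only a limit: the limit of > 100 ug/mL in this assay, at which 2 of the 4 values shown sit.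

On these data alone, the step from compound 1 to compound 4 cannot be read, so the effect of hydrogen in place of acetyl alongside isopropoxy stays open. The compounds shown also leave open how an amine or a carboxylic acid would behave in place of fluoro on that aromatic carbon.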